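The source may hold more compounds than are shown below. What is called first, only, known or untested is meant among the compounds shown, and "the series" means these compounds.

Measured so far in a physicochemical assay for solubility, using the shake flask method, in simulated intestinal fluid, measured as kinetic solubility, with a stated time of 2 h, at 25 degrees C, at pH 6.5 (on this read-out higher numbers stand for higher solubility and lower numbers for lower solubility), are two compounds.

Compound 1 (`Cc1noc(-c2nc(C)c3c(c2N)C(=O)N(Cc2ccccc2)C3=O)n1`) gives < 5000 nM as a limit of the assay and not a number.

Compound 2 (`Cc1noc(-c2nc(C)c3c(c2N)C(=O)N(C(C)c2ccccc2)C3=O)n1`) gives 10900 nM as a measured number.

Among the measured compounds shown here, compound 2 thus holds the only true number in the set, and the other entry is a limit. For the measured compounds named here, the one measured step, methyl in place of hydrogen on the saturated chain carbon, is an at least 2.1-fold higher number from compound 1 to compound 2 (0.33 log units; beyond the scatter) and it is the only guide here. Compound 3 (`Cc1noc(-c2nc(C)c3c(c2N)C(=O)N(Cc2ccccc2F)C3=O)n1`) comes with 2-fluorobenzyl in place of 1-phenylethyl on an amide-type nitrogen in a ring and so has 2-fluorobenzyl in place of 1-phenylethyl on an amide-type nitrogen in a ring. Like compound 1, it has no such methyl, while no measured step covers the fluorine. A fall in this assay is expected, estimated as a 2.2-fold lower number from compound 2 to compound 3 (0.34 log units; beyond the scatter). Compound 3 is expected at 5000 nM with an estimated range from 2000 nM to 11000 nM in this read-out.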

Compound 3, solubility: < 5000 nM
Compound 3 was reported as a limit; the forecaster's own chance of this, stated with the estimate: 45%; the middle value sits exactly at the limit.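

In this assay, 2-fluorobenzyl in place of 1-phenylethyl on the amide-type nitrogen in a ring gives an at least 2.1-fold lower number from compound 2 to compound 3 (0.33 log units; beyond the scatter). Compound 3 gives < 5000 nM, which is a limit and not a number. The fluoro group therefore does not bring compound 3 to a measured number as the methyl of compound 2 does, and the step from compound 1 to compound 3 cannot be read because both values are limits: the limit of < 5000 nM in this assay, at which 2 of the 3 values shown sit.

Among the compounds shown here, compound 2 remains the only compound with a true number, so how far compound 1 and compound 3 lie from the limit stays open. Also open, from the compounds shown here alone, is what this assay would show for an ethyl group in place of the methyl on the chain carbon, or for an amine on the phenyl ring.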